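The source may hold more compounds than are shown below. What is called first, only, known or untested is meant among the compounds shown, and "the series" means these compounds.

For the measured compounds named here, in a functional assay on NCI-H460 cells (Homo sapiens) for cytotoxicity, read by MTT assay, with a stated time of 68 h (a higher number here means a weaker inhibitor, a lower number a stronger inhibitor), compound 2 `O=C(Nc1cccc(-c2ccccc2)c1)C(Cl)Cl` gives 20200 nM, the only actual number so far. Compound 1 `O=C(Nc1cccc(-c2ccc(F)cc2)c1)C(Cl)Cl` gives > 50000 nM, which is a limit of the assay and not a number. The next structure, compound 3 `O=C(Nc1cccc(-c2ccc(Cl)cc2)c1)C(Cl)Cl`, differs from compound 2 by chloro in place of hydrogen on an aromatic carbon, para to a large group. Going by the values given here, one measured step bears on this change: an at least 2.4-fold lower number from compound 1 to compound 2 (0.39 log units; beyond the scatter), with hydrogen in place of fluoro on an aromatic carbon. Read in reverse, that step links a halogen with a higher number, although it rests on a single pair and compound 3 carries chloro, not fluoro. A modest move to a higher number in this assay is therefore expected, similar in size to the measured step but uncertain in direction. The expected change is a 2.1-fold higher number from compound 2 to compound 3 (0.32 log units; beyond the scatter). For compound 3, the estimated value is 42000 nM, with an expected range from 10000 nM to 50000 nM.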

Compound 3, half-maximal inhibitory concentration: > 50000 nM
Compound 3: only a limit was reported (the forecaster's own chance of this, stated with the estimate: 40%); at least 1.1-fold (0.07 log units) between middle value and limit.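

In this assay, chloro in place of hydrogen on an aromatic carbon, para to a large group, gives an at least 2.4-fold higher number from compound 2 to compound 3 (0.39 log units; beyond the scatter), so the change now has a measured step of its own and no longer rests on a reading of the fluoro pair in reverse. With this result, two different halogens at this position, fluoro in compound 1 and chloro in compound 3, each stand on the higher side of compound 2, which carries hydrogen there, and the direction that was uncertain beforehand is settled for these three compounds. The step between the two halogen compounds cannot be read, because each of them gives only a limit of the assay and not a number: the limit of > 50000 nM in this assay, at which 2 of the 3 values shown sit.

On these data alone, how far compound 1 and compound 3 lie from that limit stays open, and so does any ranking of fluoro against chloro. The compounds shown also leave open what an amine, a methoxy group or a carboxylic acid on the same aromatic carbon would do, since only hydrogen and the two halogens appear there.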